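The compounds below may be only part of what the source reports. "The series", "measured", "known", "first", "only" and "open" are said of these compounds alone.

Measured so far:
- compound 1, `CCCCCCCCCCCCCCNc1nc(SCc2ccc(C(F)(F)F)cc2)nc2ccccc12`: > 50000 nM (a limit of the assay, not a number)
- compound 2, `FC(F)(F)c1ccc(CSc2nc(N3CCCCC3)c3ccccc3n2)cc1`: 28400 nM
- compound 3, `FC(F)(F)c1ccc(CSc2nc(Nc3ccccc3)c3ccccc3n2)cc1`: 18400 nM

In a functional assay on MDA-MB-231 cells (Homo sapiens) for cytotoxicity, read by MTT assay, with a stated time of 72 h (on this read-out lower numbers stand for stronger inhibition and higher numbers for weaker inhibition), compound 1 reaches only the limit (the limit of > 50000 nM in this assay, at which 1 of the 3 values shown sits), so no number is known for it. Compound 2 stands at the highest of the two numbers, and its nearest neighbour is compound 3, at a 1.5-fold lower number from compound 2 to compound 3 (0.19 log units; within the scatter); with only these two numbers and one limit, no order among them can be claimed.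

Compound 4, `CCOc1ccccc1Nc1nc(SCc2ccc(C(F)(F)F)cc2)nc2ccccc12`, differs from compound 2 in one place: (2-ethoxyphenyl)amino in place of piperidin-1-yl on an aromatic carbon. Within the data shown here, the only measured step that bears on this is the one from compound 2 to compound 3, where a group of the same kind replaced the same piperidin-1-yl and the number changed by a 1.5-fold lower number from compound 2 to compound 3 (0.19 log units; within the scatter), a step inside the scatter. A step of similar size is therefore expected for compound 4 in this assay, leaning slightly towards a lower number but not clearly beyond the scatter. The expected step from compound 2 to compound 4 is a 1.4-fold lower number from compound 2 to compound 4 (0.15 log units; within the scatter). Compound 4 is accordingly estimated at 20000 nM, with a range from 8000 nM to 50000 nM.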

Compound 4, half-maximal inhibitory concentration: > 50000 nM
Compound 4 gave a limit, no number; the forecaster's own chance of this, stated with the estimate: 12%; middle value at least 2.5-fold (0.39 log units) away from the limit.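

Ethoxy in place of hydrogen on the anilino group of compound 3 gives an at least 2.7-fold higher number from compound 3 to compound 4 (0.43 log units; beyond the scatter) in this assay, the first step shown at this position that lies beyond the scatter. Measured against piperidin-1-yl, the (2-ethoxyphenyl)amino group gives an at least 1.7-fold higher number from compound 2 to compound 4 (0.24 log units; that floor lies within the scatter), which is only a floor, so this comparison alone shows no clear change. Compound 4 therefore gives no number, only a limit, the same one that compound 1 reaches: the limit of > 50000 nM in this assay, at which 2 of the 4 values shown sit.

The compounds shown leave open whether this loss belongs to ethoxy in particular, or whether a methoxy group, a fluorine atom or an amine on the same aromatic ring would give a similar result. On these data alone, how much weaker compound 4 truly is also stays unknown, since a limit gives no number to compare.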